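Swapping an Amine for a Hydroxyl on the Side Chain

This account rests on a few compounds, and the source may have more. Where it says the series, first, only, none or still open, it means among the compounds named here.

Compound 1 `Cc1c2c(n3c1CCN(C(=O)CN)C[C@@H](C)[C@H](C)Nc1cc-3ccc1C(N)=O)CC(C)(C)CC2=O` carries an aminomethyl group on the carbonyl of its ring-bound amide. In a functional assay on HCT-116 cells (Homo sapiens) for antiproliferative activity (a higher number here means a weaker inhibitor, a lower number a stronger inhibitor), compound 1 gives 216 nM, the highest of the two numbers recorded so far. Compound 2 `COCCC(=O)N1CCCc2c(C)c3c(n2-c2ccc(C(N)=O)c(c2)N[C@@H](C)[C@@H]1C)CC(C)(C)CC3=O`, which bears a different side chain on the corresponding carbonyl, gives 55 nM in this assay, a clearly stronger result. Compound 3 `Cc1c2c(n3c1CCN(C(=O)[C@H](C)O)C[C@@H](C)[C@H](C)Nc1cc-3ccc1C(N)=O)CC(C)(C)CC2=O` has not yet been tested. Compared with compound 1 it shows a single change: 1-hydroxyethyl in place of aminomethyl on a carbonyl carbon. The basic amine is thus replaced by a hydroxyl, and a defined stereocentre appears. Because compound 2 reaches 55 nM without any amine on its side chain, a small gain for compound 3 is expected, though a result within the scatter would also fit. The expected step of a 1.8-fold lower number from compound 1 to compound 3 (0.26 log units; within the scatter) is a modest drop in the number. Compound 3 is estimated at 120 nM, with a range from 50 nM to 300 nM.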

Compound 3, half-maximal inhibitory concentration: 42 nM
Compound 3: middle estimate off by 2.9-fold (0.46 log units), on the high side; measured number outside the range, below it.
By their numbers in this assay, from the lowest: compounds 3 and 2 (each within the scatter of the next); then compound 1.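

In this assay, putting 1-hydroxyethyl in place of aminomethyl on this carbonyl carbon gives a 5.1-fold lower number from compound 1 to compound 3 (0.71 log units; beyond the scatter), so a change of only a few atoms at this position moves the number beyond the scatter. Nothing else differs within this pair. It also shows directly that an amine on this side chain is not needed to reach a lower number on this core. The two groups have the same counts of hydrogen-bond donors and acceptors, and no measurement at hand accounts for the step.

The swap changes three things at once: nitrogen becomes oxygen, a carbon is added, and a defined stereocentre appears, and these compounds cannot separate them. Hydroxymethyl, 1-aminoethyl and the opposite stereoisomer of 1-hydroxyethyl at this carbonyl carbon would each isolate one of these changes.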